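Loss of one chloro from compound 2

The source may report more compounds than this note shows. Statements on the series, on what has been measured and on what is new or still open speak of the compounds shown alone.

Compound 1 `O=C(c1cc(Cl)cc(Cl)c1)N1CCCN(C(=O)c2cc(Cl)cc(Cl)c2)C1=S` gives 30000 nM in a functional assay on MT4 cells (Homo sapiens) for antiproliferative activity, read by MTT assay; on this read-out lower numbers stand for stronger inhibition and higher numbers for weaker inhibition. Compound 2 `O=CN1CCN(c2ccc(Cl)cc2Cl)C1=S` reaches only a limit of the assay, > 100000 nM in this assay. Compound 2 therefore sits at the weak end of the two numbers shown (the limit of > 100000 nM in this assay, at which 1 of the 2 values shown sits). Compound 3 `O=CN1CCN(c2ccc(Cl)cc2)C1=S` differs from compound 2 by hydrogen in place of chloro on an aromatic carbon. Within the data shown here, no measured step of this kind exists in the set. Compound 3 is expected at 150000 nM, between 60000 nM and 400000 nM, most likely again a limit. The expected step that the limit leaves unreadable from compound 2 to compound 3 is estimated to stay within the scatter in this assay, in no clear direction.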

Compound 3, half-maximal inhibitory concentration: 27000 nM
For compound 3 the middle estimate is 5.6-fold (0.74 log units) above the measured one; measured number below the stated range.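

In this assay, the position ortho to the group of 8 heavy atoms responds to the exchange of chloro for hydrogen, giving an at least 3.7-fold lower number from compound 2 to compound 3 (0.56 log units; beyond the scatter). The direction is toward stronger inhibition, while the size remains only a bound, as the value for compound 2 is a limit of the assay: the limit of > 100000 nM in this assay, at which 1 of the 3 values shown sits.

From the compounds shown here alone, the full size of this step stays open, as does the role of the remaining chloro group. Whether a methyl, a methoxy or an amine on this aromatic carbon would match hydrogen or chloro also remains unresolved.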